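The source may hold more compounds than are shown below. What is called first, only, known or untested is meant among the compounds shown, and "the series" means these compounds.

Measured so far:
compound 1 `CCCCCCOc1cc([N+](=O)[O-])ccc1NS(C)(=O)=O` — 2670 nM
compound 2 `COc1cc([N+](=O)[O-])ccc1NS(C)(=O)=O` — > 25000 nM
compound 3 `CCCCCCOc1cc([N+](=O)[O-])ccc1N(C)S(C)(=O)=O` — 4490 nM

In an assay on SK-BR-3 cells for inhibition of Aromatase (Homo sapiens) (a higher number here means a weaker inhibitor, a lower number a stronger inhibitor), compound 1 gives 2670 nM. For compound 2 this assay reports only a limit, > 25000 nM, not a number. Compound 3 gives 4490 nM in this assay.

The change from compound 1 to compound 2 is hydrogen in place of pentyl on a saturated chain carbon bound to an oxygen on an aromatic ring. It brings an at least 9.3-fold higher number from compound 1 to compound 2 (0.97 log units; beyond the scatter), the size of which is bounded by the limit of > 25000 nM in this assay, at which 1 of the 3 values shown sits.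

Compound 3 differs from compound 1 by methyl in place of hydrogen on a sulfonamide nitrogen, a core change that gives a 1.7-fold higher number from compound 1 to compound 3 (0.23 log units; within the scatter).

Compound 4 `COc1cc([N+](=O)[O-])ccc1N(C)S(C)(=O)=O` has not yet been measured. It differs from compound 3 by hydrogen in place of pentyl on a saturated chain carbon bound to an oxygen on an aromatic ring, the same change as from compound 1 to compound 2, at the same place. Its step is therefore expected to be of similar size, an 8.9-fold higher number from compound 3 to compound 4 (0.95 log units; beyond the scatter), which rests on the weakening seen in an at least 9.3-fold higher number from compound 1 to compound 2 (0.97 log units; beyond the scatter) and on the starting point of compound 3 at 4490 nM. Compound 4 is expected to give about 40000 nM, between 12000 nM and 150000 nM, most likely reported as a limit.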

Compound 4, half-maximal inhibitory concentration: > 25000 nM
Compound 4: no number, only a limit; the forecaster's own chance of this, stated with the estimate: 75%; the middle value lies beyond the limit too.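

Cutting the hexyloxy group back to methoxy weakens inhibition on the second core as well, with an at least 5.5-fold higher number from compound 3 to compound 4 (0.74 log units; beyond the scatter), so the direction of this change carries over from one core to the other in these two pairs. Set side by side, the two steps compare as follows: the same change on two cores in this assay, an at least 9.3-fold higher number (0.97 log units; beyond the scatter) from compound 1 to compound 2 and an at least 5.5-fold higher number (0.74 log units; beyond the scatter) from compound 3 to compound 4; the limit leaves it open whether they differ. What this does not show is how large the loss truly is on either core, and the step that adds the methyl on the sulfonamide nitrogen to the methoxy compounds cannot be read either, since neither methoxy compound has an exact value: the limit of > 25000 nM in this assay, at which 2 of the 4 values shown sit.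

The compounds shown leave open how inhibition changes with chains of other lengths on the oxygen, such as a butyl chain or a longer chain such as octyl, and so where along the chain the loss sets in. They also leave open whether a hexyl chain ending in a carboxylic acid or an amine would behave like the plain hexyl chain.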